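The source may hold more compounds than are shown below. What is called first, only, known or untested is meant among the compounds shown, and "the series" means these compounds.

Measured so far in a functional assay on HT-29 cells (Homo sapiens) for inhibition, read by sulforhodamine B assay, with a stated time of 48 h; on this read-out lower numbers stand for stronger inhibition of growth and higher numbers for weaker inhibition of growth:
- compound 1 `COc1ccc(/C=C/C2(C)C=CC(=O)O2)c(OC)c1`: 57500 nM
- compound 2 `COc1ccc(/C=C/C2(C)C=CC(=O)O2)cc1OC`: 927000 nM
- compound 3 `COc1ccc(/C=C/C2(C)C=CC(=O)O2)c(OC)c1OC`: 133000 nM

Compound 2 gives the highest number of the three, 927000 nM. Compound 4 `COc1cc(OC)c(OC)cc1/C=C/C1(C)C=CC(=O)O1` has not yet been measured. It differs from compound 2 by methoxy in place of hydrogen on an aromatic carbon. Two measured steps make the same kind of change. The closer one is a 7.0-fold lower number from compound 2 to compound 3 (0.84 log units; beyond the scatter), and there the new methoxy of compound 3 likewise stands ortho to a group of 9 heavy atoms. The other, a 2.3-fold higher number from compound 1 to compound 3 (0.36 log units; beyond the scatter), runs the opposite way, so compound 1 goes against any rule that added methoxy lowers the number. For the measured compounds named here, compound 4 also carries every methoxy group of compound 1, but its added methoxy stands elsewhere on the ring than in compound 3, a placement no measurement yet covers. On the evidence of compound 3, with its 133000 nM, a lower number than that of compound 2 is expected in this assay. The expected change is a 7.1-fold lower number from compound 2 to compound 4 (0.85 log units; beyond the scatter), a modest step beyond the scatter. For compound 4 the estimated value is 130000 nM, with an expected range from 45000 nM to 380000 nM.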

Compound 4, concentration for total growth inhibition: 127000 nM
The estimate for compound 4 lay 1.0-fold (0.01 log units) above the measured number; low and high end bracket the measured number.
By their numbers in this assay, from the lowest: compound 1; then compounds 4 and 3 (each within the scatter of the next); then compound 2.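

In this assay, for the compounds shown here, a methoxy that stands ortho to a group of 9 heavy atoms, meta to a methoxy group and para to a methoxy group gives a 7.3-fold lower number from compound 2 to compound 4 (0.86 log units; beyond the scatter), and the result lies within the scatter of the value of compound 3, so this newly covered placement and the one in compound 3 cannot be told apart here. Read from the other parent, the same kind of change gives a 2.2-fold higher number from compound 1 to compound 4 (0.34 log units; beyond the scatter), so both placements now raise the number on the core of compound 1 and lower it on the core of compound 2. No single rule for an added methoxy therefore holds across these compounds, whichever placement is taken, as the two steps lie further apart than two such steps would scatter: the same change on two cores in this assay, a 7.0-fold lower number (0.84 log units; beyond the scatter) from compound 2 to compound 3 and a 2.2-fold higher number (0.34 log units; beyond the scatter) from compound 1 to compound 4, 15-fold (1.19 log units) apart, beyond the scatter of two such steps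

Every compound shown carries only methoxy groups on the aromatic ring, so what a hydroxyl, an amine or a carboxylic acid would do at this place stays open. The data also leave open whether a longer chain such as ethoxy would follow the same split between the two parents.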